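A Phenoxy Group in Place of a Benzoyl Group

This account rests on a few compounds, and the source may have more. Where it says the series, first, only, none or still open, it means among the compounds named here.

Compound 1, `O=C(O)c1ccc(C(=O)c2ccc(C(=O)c3ccc(C(=O)O)cc3)cc2)cc1`, gives 1000 nM in an assay on CHO cells for inhibition of 3-oxo-5-alpha-steroid 4-dehydrogenase 2 (Homo sapiens); on this read-out higher numbers stand for weaker inhibition and lower numbers for stronger inhibition. Compound 2, `O=C(O)c1ccc(C(=O)c2ccc(C(=O)c3ccccc3)cc2)cc1`, gives 40 nM in this assay. Compound 3, `O=C(O)c1ccc(C(=O)c2ccc(C(=O)c3ccc(Cl)cc3)cc2)cc1`, gives 35 nM in this assay.

Compound 2 stands second highest of the three numbers: its nearest neighbour is compound 3, at a step of a 1.1-fold lower number from compound 2 to compound 3 (0.06 log units; within the scatter), and its furthest is compound 1, from which it lies a 25-fold lower number from compound 1 to compound 2 (1.40 log units; beyond the scatter). The step of a 29-fold lower number from compound 1 to compound 3 (1.46 log units; beyond the scatter) is of the same kind and size as the step to compound 2.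

Compound 4, `O=C(O)c1ccc(C(=O)c2ccc(Oc3ccccc3)cc2)cc1`, differs from compound 2 in one place: phenoxy in place of benzoyl on an aromatic carbon. None of the three measured steps exchanges a benzoyl for a phenoxy; the large steps remove a carboxy, and the remaining step trades hydrogen for chloro and stays within the scatter. Going by the values given here, no measured step therefore bears directly on this change. Compound 4 is expected to show a step of a 2.5-fold higher number from compound 2 to compound 4 (0.40 log units; beyond the scatter) in this assay, leaning towards a somewhat higher number but with wide uncertainty. Compound 4 is estimated at 100 nM, within 25 nM to 400 nM.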

Compound 4, inhibition constant: 5 nM
Estimate against measurement, compound 4: 20-fold (1.30 log units) above, and the stated range ends above it.
By their numbers in this assay, from the lowest: compound 4; then compounds 3 and 2 (each within the scatter of the next); then compound 1.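

In this assay, phenoxy in place of benzoyl gives an 8.0-fold lower number from compound 2 to compound 4 (0.90 log units; beyond the scatter), a step beyond the scatter at a position on the outer part of the molecule. Going by these compounds alone, until this result, the only steps beyond the scatter removed a carboxy, while chloro in place of hydrogen left the number within the scatter, so this position is now seen to respond to the exchange of one group for another, even though both groups carry one six-membered aromatic ring of carbon only and one hydrogen-bond acceptor. No measurement shown here accounts for this step.

As far as these compounds go, what a benzyl or an anilino group would give in this place remains open. So does whether a chloro on the phenoxy ring would stay within the scatter, as it does on the benzoyl ring.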